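The source may report more compounds than this note shows. Statements on the series, on what has been measured and on what is new or still open speak of the compounds shown alone.

In an ADME assay on MRC5 cells (Homo sapiens) for inhibition, with a stated time of 72 h (a higher number here means that more compound is needed for the effect, a lower number that less compound is needed), compound 1 `COc1cccc(OC)c1C(=O)Nc1c[nH]nc1C(=O)NC1CC1` gives > 50000 nM, and this value is a limit of the assay rather than a number. Compound 2 `CO[C@H]1CC[C@H](NC(=O)c2n[nH]cc2NC(=O)c2ccc(-c3ccccc3)o2)CC1` gives 100 nM in this assay. Among the compounds with values here, no step between two measured compounds that differ in a single place is available, so the two values stand on their own; compound 1 sits at the limit of > 50000 nM in this assay, at which 1 of the 2 values shown sits. Compound 3 `COc1cccc(OC)c1C(=O)Nc1c[nH]nc1C(=O)NCc1ncccc1C` has not yet been measured in this assay. It differs from compound 1 by (3-methylpyridin-2-yl)methyl in place of cyclopropyl on an amide-type nitrogen. Within the data shown here, with compound 1 at the limit, no measured step fixes a direction for this change. Compound 3 is expected to give 40000 nM in this assay, with a range from 8000 nM to 50000 nM. The step of an at least 1.2-fold lower number from compound 1 to compound 3 (0.09 log units; that floor lies within the scatter) is expected to be none beyond the usual scatter, and a limit rather than a number is thought the most likely outcome for compound 3.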

Compound 3, half-maximal effective concentration: > 50000 nM
Compound 3 ended at the assay's limit (the forecaster's own chance of this, stated with the estimate: 65%); middle value at least 1.2-fold (0.09 log units) away from the limit.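

Compound 1 and compound 3 both stand at a limit rather than a number, and no step between them can be read: the limit of > 50000 nM in this assay, at which 2 of the 3 values shown sit.

The compounds shown leave open how far, if at all, (3-methylpyridin-2-yl)methyl in place of cyclopropyl on an amide-type nitrogen shifts the read-out in this assay.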